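This account rests on a few compounds, and the source may have more. Where it says the series, first, only, none or still open, it means among the compounds named here.

Working notes on the series. Compound 1 `CCOC(=O)c1ccc(-c2nn(Cc3ccccc3Cl)c3ccccc23)cc1` and compound 2 `CCOC(=O)c1ccc(-c2nn(Cc3cccc(Cl)c3)c3ccccc23)cc1` share one core and differ only in the substituted phenyl carried on a saturated chain carbon bound to an aromatic nitrogen. In a functional assay on cells (Platelet, Homo sapiens) for inhibition (a lower number here means a stronger inhibitor, a higher number a weaker inhibitor), compound 1 gives only a limit, > 10000 nM. In this assay compound 2 likewise gives only a limit, > 10000 nM. The step that the two limits leave unreadable from compound 1 to compound 2 is therefore unreadable, since both values sit at the limit of > 10000 nM in this assay, at which 2 of the 2 values shown sit. Compound 2 thus stands at the limit of this assay, with no number that would place it against compound 1.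

Compound 3 `CCOC(=O)c1ccc(-c2nn(Cc3ccccc3OC)c3ccccc23)cc1` differs from compound 2 by 2-methoxyphenyl in place of 3-chlorophenyl on a saturated chain carbon bound to an aromatic nitrogen. Within the data shown here, the only measured step in this assay, a step that the two limits leave unreadable from compound 1 to compound 2, is itself not readable, so no size and no direction can be drawn from it for the exchange of 3-chlorophenyl for 2-methoxyphenyl. Set against a limit, the expected step that the limit leaves unreadable from compound 2 to compound 3 cannot be read as a change beyond the scatter. Compound 3 is expected to give 15000 nM in this assay, within 4000 nM to 60000 nM, and most probably again only as a limit.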

Compound 3, half-maximal inhibitory concentration: > 10000 nM
Compound 3: a limit, no number; the forecaster's own chance of this, stated with the estimate: 80%; the middle value does not contradict the limit.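

In this assay compound 3 gives > 10000 nM, a limit and not a number. No step among compound 1, compound 2 and compound 3 can be read: the limit of > 10000 nM in this assay, at which 3 of the 3 values shown sit.

The compounds shown leave open whether any substituted phenyl at this place on the shared core gives a measurable inhibition in this assay, and how these substituents compare.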